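Adding fluoro to the formyl-bearing aryl group

The source may report more compounds than this note shows. Statements on the series, on what has been measured and on what is new or still open speak of the compounds shown alone.

Compound 1 `CC(C)n1nccc1-c1ncccc1COc1cccnc1C=O`: 0.7 h
Compound 2 `CC(C)n1nccc1-c1ncccc1COc1ccccc1C=O`: 2.1 h

In an ADME assay on the whole organism (blood, Rattus norvegicus, strain Sprague-Dawley) for metabolic stability, read by LC-MS (a higher number here means that the compound lasts longer, a lower number that the compound disappears faster), compound 2 has the higher of the two measured half-lives at 2.1 h, while compound 1 gives 0.7 h. The next compound to be tested is compound 3 `CC(C)n1nccc1-c1ncccc1COc1cccc(F)c1C=O`. It differs from compound 2 by one substitution: fluoro in place of hydrogen on an aromatic carbon. This is fluoro in place of hydrogen on an aromatic carbon, ortho to a formyl group and meta to a large group.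

Among the measured compounds shown here, no measured step shows this exchange, so the data give no direct guide to it. For the measured compounds named here, the only step available is a 3.0-fold higher number from compound 1 to compound 2 (0.48 log units; beyond the scatter), a modest change in which 2-formylphenyl takes the place of 2-formylpyridin-3-yl. It bears on the question only loosely: it shows that a change in this part of the molecule can move the half-life beyond the scatter, but it says nothing about fluoro. No shift beyond the scatter is therefore expected, and neither direction is favoured, so the estimated step is a 1.1-fold lower number from compound 2 to compound 3 (0.02 log units; within the scatter). For compound 3, the expected half-life is 2 h, within an estimated range of 1 h to 4 h.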

Compound 3, half-life: 2.7 h
The estimate for compound 3 lay 1.4-fold (0.13 log units) below the measured number; low and high end bracket the measured number.
By their numbers in this assay, from the lowest: compound 1; then compounds 2 and 3 (each within the scatter of the next).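

In this assay the new step is a 1.3-fold higher number from compound 2 to compound 3 (0.11 log units; within the scatter) and so lies within the scatter: fluoro in place of hydrogen on an aromatic carbon, ortho to a formyl group and meta to a large group, gives no shift in half-life that can be told from repeated measurement. The earlier step of a 3.0-fold higher number from compound 1 to compound 2 (0.48 log units; beyond the scatter) showed only that exchanging the whole formyl-bearing aryl group can move the half-life beyond the scatter, whereas this result shows that the aromatic carbon tolerates one added fluorine atom without such a move. No supporting measurement is available to account for this outcome.

What the compounds shown leave open is whether a larger group at this same place, such as chloro, methyl or methoxy, would also leave the half-life within the scatter, and whether fluoro on the other free carbons of this ring would do the same. From the compounds shown here alone, it also remains open whether fluoro would give a similar step on the 2-formylpyridin-3-yl group of compound 1, whose half-life is the shortest of the series.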